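Swapping 2-fluorophenyl for 3-nitrophenyl in compound 4

A few compounds are considered here, and "the series" means these few. Any claim that something is new, unique, unknown or untested is made for them only; others in the source may bear on it.

Measured in a functional assay on MCF7 cells (Homo sapiens) for cytotoxicity, read by MTT assay, with a stated time of 96 h; on this read-out higher numbers stand for weaker inhibition and lower numbers for stronger inhibition:
- Compound 1 `COc1cc(C(=O)c2cn(-c3cccc(N)c3)cc2-c2ccccc2F)cc(OC)c1OC` gives 17 nM
- Compound 2 `COc1cc(C(=O)c2cn(-c3cccc(N)c3)cc2-c2cccc([N+](=O)[O-])c2)cc(OC)c1OC` gives 510 nM
- Compound 3 `COc1cc(C(=O)c2cn(-c3ccc(C)cc3)cc2-c2ccccc2F)cc(OC)c1OC` gives 44 nM

Compound 3, at 44 nM, holds the second highest of the three numbers. It sits closer to compound 1 than to compound 2. Compound 4 `COc1cc(C(=O)c2cn(-c3ccc(C)cc3)cc2-c2cccc([N+](=O)[O-])c2)cc(OC)c1OC` keeps the 4-methylphenyl group of compound 3 and carries 3-nitrophenyl in place of 2-fluorophenyl on an aromatic carbon.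

The same swap has been measured once, with 3-aminophenyl on the aromatic nitrogen, and it gave a 30-fold higher number from compound 1 to compound 2 (1.48 log units; beyond the scatter). The change at that nitrogen gave a 2.6-fold higher number from compound 1 to compound 3 (0.41 log units; beyond the scatter), so the two groups do not leave the number untouched, and the swap may not carry over in full size from this single example. A large step toward a higher number is therefore expected in this assay. The estimated step is a 27-fold higher number from compound 3 to compound 4 (1.44 log units; beyond the scatter). For compound 4 the expected value is 1200 nM, with an estimated range of 350 nM to 4000 nM.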

Compound 4, half-maximal inhibitory concentration: 210 nM
Estimate against measurement, compound 4: 5.7-fold (0.76 log units) above; measured number below the stated range.
By their numbers in this assay, from the lowest: compound 1; then compound 3; then compound 4; then compound 2.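

In this assay, the effect of 3-nitrophenyl in place of 2-fluorophenyl proves to depend on the group on the ring nitrogen: with 4-methylphenyl there, the change gives a 4.8-fold higher number from compound 3 to compound 4 (0.68 log units; beyond the scatter), a smaller step than the one seen with 3-aminophenyl: the same change on two cores in this assay, a 30-fold higher number (1.48 log units; beyond the scatter) from compound 1 to compound 2 and a 4.8-fold higher number (0.68 log units; beyond the scatter) from compound 3 to compound 4, 6.3-fold (0.80 log units) apart, beyond the scatter of two such steps. Read the other way, 4-methylphenyl in place of 3-aminophenyl gives a 2.4-fold lower number from compound 2 to compound 4 (0.39 log units; beyond the scatter) when 3-nitrophenyl is present, the opposite direction to its step when 2-fluorophenyl is present: the same change on two cores in this assay, a 2.6-fold higher number (0.41 log units; beyond the scatter) from compound 1 to compound 3 and a 2.4-fold lower number (0.39 log units; beyond the scatter) from compound 2 to compound 4, 6.3-fold (0.80 log units) apart, beyond the scatter of two such steps. The two sites therefore do not act independently in these four compounds, and neither step carries over unchanged.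

What lies behind this dependence cannot be told from these compounds. As far as these compounds go, it also remains open whether it would persist with a 3-aminophenyl group on the aromatic carbon or a 4-methoxyphenyl group on the ring nitrogen.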